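From dimethylsulfamoyl to methylsulfonyl on the shared core

This account rests on a few compounds, and the source may have more. Where it says the series, first, only, none or still open, it means among the compounds named here.

Three related compounds have so far been followed in an in vivo ADME assay on the whole organism (strain BALB/c) for pharmacokinetics, with Mus musculus as the target, read by LC-MS, at a dose of 5 mg/kg by the oral route (a higher number here means faster removal of the compound, a lower number slower removal), after oral dosing. Compound 1 (`CN(C)S(=O)(=O)c1ccc(F)c(C#Cc2cc(Cl)ccc2OCC(=O)O)c1`) gives 10 mL/min/kg and compound 2 (`CC(C)S(=O)(=O)c1ccc(Cl)c(C#Cc2cc(Cl)ccc2OCC(=O)O)c1`) gives 11.7 mL/min/kg in this work, two values within the scatter of each other. Compound 3 (`Cc1ccc(S(=O)(=O)N2CCOCC2)cc1C#Cc1cc(Cl)ccc1OCC(=O)O`) gives 31.7 mL/min/kg as its clearance, a number above that of compound 1 by more than the scatter.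

Compound 4 (`CS(=O)(=O)c1ccc(F)c(C#Cc2cc(Cl)ccc2OCC(=O)O)c1`) has not yet been measured. It carries methyl in place of dimethylamino on a sulfonyl sulfur compared with compound 1. Within the data shown here, no measured pair isolates this change, so any step remains an expectation. Compound 2, which also lacks the dimethylamino group, gives 11.7 mL/min/kg as its clearance, and this is the closest guide available. No step beyond the scatter is expected in this assay in either direction. The estimated step (a 1.2-fold higher number from compound 1 to compound 4 (0.08 log units; within the scatter)) is small. Compound 4 is expected at 12 mL/min/kg (estimated range 6 mL/min/kg to 24 mL/min/kg).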

Compound 4, clearance: 6.67 mL/min/kg
For compound 4 the middle estimate is 1.8-fold (0.26 log units) above the measured one; the measured number falls inside the stated range.
By their numbers in this assay, from the lowest: compounds 4, 1 and 2 (each within the scatter of the next); then compound 3.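

Among these compounds, compound 1 and compound 4 form the first measured pair that isolates a single change at this position, and in this assay methyl in place of dimethylamino on a sulfonyl sulfur gives a 1.5-fold lower number from compound 1 to compound 4 (0.18 log units; within the scatter). On this core, then, going from dimethylsulfamoyl to methylsulfonyl does not move clearance beyond the scatter, so the nitrogen and its two carbons can be exchanged for a single methyl without a measurable step in this read-out. No measurement at hand speaks to what lies behind this result.

The compounds shown leave open whether an ethyl or cyclopropyl group, or an unsubstituted amino group, on the same sulfonyl sulfur would also stay within the scatter of compound 4. One pair also cannot tell whether this exchange would behave alike on a different core.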